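Swapping 1,3-oxazol-2-yl for pyridin-4-yl on compound 2

A few compounds are considered here, and "the series" means these few. Any claim that something is new, unique, unknown or untested is made for them only; others in the source may bear on it.

compound 1 `COc1cc(C(=O)c2cn(-c3cccc(C)c3)cc2-c2ncco2)cc(OC)c1OC`: 75 nM
compound 2 `COc1cc(C(=O)c2cn(-c3ccc(C)cc3)cc2-c2ncco2)cc(OC)c1OC`: 42 nM

In a functional assay on MCF7 cells (Homo sapiens) for inhibition, with a stated time of 96 h (on this read-out lower numbers stand for stronger inhibition and higher numbers for weaker inhibition), compound 2, at 42 nM, and compound 1, at 75 nM, lie within the usual scatter of each other, so the two cannot be ranked. Among the measured compounds shown here, the one measured step, a 1.8-fold lower number from compound 1 to compound 2 (0.25 log units; within the scatter), is a swap of 3-methylphenyl for 4-methylphenyl on an aromatic nitrogen.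

Compound 3 `COc1cc(C(=O)c2cn(-c3ccc(C)cc3)cc2-c2ccncc2)cc(OC)c1OC` keeps the 4-methylphenyl group of compound 2 and differs elsewhere, with pyridin-4-yl in place of 1,3-oxazol-2-yl on an aromatic carbon. For the measured compounds named here, no measured step touches this place, so the swap on the nitrogen says little about it. It shows only how small a change can be in this pair. The expectation therefore starts from compound 2 at 42 nM and leans cautiously towards a somewhat higher number, since an untested group replaces one present in both measured compounds. The expected size and direction are a 1.9-fold higher number from compound 2 to compound 3 (0.28 log units; within the scatter), and this estimate is loose. For compound 3 the estimated value in this assay is 80 nM, with an expected range from 15 nM to 400 nM.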

Compound 3, half-maximal inhibitory concentration: 9 nM
For compound 3 the middle estimate is 8.9-fold (0.95 log units) above the measured one; the measured number lies below the stated range.
By their numbers in this assay, from the lowest: compound 3; then compounds 2 and 1 (each within the scatter of the next).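

In this assay, exchanging 1,3-oxazol-2-yl for pyridin-4-yl on this aromatic carbon gives a 4.7-fold lower number from compound 2 to compound 3 (0.67 log units; beyond the scatter) and so, unlike the methyl swap on the aromatic nitrogen, this change produces a difference that clears the usual scatter, though only a modest one. The place therefore accepts a six-membered aromatic ring with 1 hetero atom in place of a five-membered one with 2 hetero atoms, and potency on these cells improves rather than being lost. The exchange alters ring size, atom count and hydrogen-bond acceptor count all at once, so this single pair cannot show which of these differences matters, and nothing at hand explains the gain.

A phenyl or pyridin-3-yl group at this place would help separate the role of the ring size from that of the ring nitrogen and its location. Going by these compounds, it also remains open whether pyridin-4-yl brings a similar gain alongside the 3-methylphenyl group of compound 1, or alongside a larger group on the aromatic nitrogen, such as 4-methoxyphenyl.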